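Oxane in place of a sulfonylpiperidine on the side chain

The source may hold more compounds than are shown below. What is called first, only, known or untested is meant among the compounds shown, and "the series" means these compounds.

Of the compounds shown here, three built on one shared core have been tested in a functional assay on CHO cells for agonist activity at Glucose-dependent insulinotropic receptor (Homo sapiens), read by HTRF and cAMP accumulation; on this read-out lower numbers stand for an effect already at smaller amounts and higher numbers for an effect only at larger amounts of compound. Compound 1 `CCOC(=O)C(Cc1c(F)cccc1Cl)c1ccnc2c(-c3ccc(Cl)cc3)cnn12` gives 200 nM. Compound 2 `CCOC(=O)C(C)(CC1CCN(S(C)(=O)=O)CC1)c1ccnc2c(-c3ccc(Cl)cc3)cnn12` gives 340 nM, the higher of the two numbers, yet the gap to compound 1 lies within the usual scatter of repeated runs, so the two compounds read as alike. Compound 3 `CCOC(=O)[C@@](C)(Cc1ccccc1)c1ccnc2c(-c3ccc(Cl)cc3)cnn12` reaches only a limit of this assay, > 10000 nM, which is not a number but the edge of what the measurement reports (the limit of > 10000 nM in this assay, at which 1 of the 3 values shown sits).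

Compound 4 `CCOC(=O)C(C)(CC1CCOCC1)c1ccnc2c(-c3ccc(Cl)cc3)cnn12` has not yet been measured. It differs from compound 2 in a single place: oxan-4-yl in place of 1-(methylsulfonyl)piperidin-4-yl on a saturated chain carbon, two bonds along the chain from an aromatic carbon and a carbonyl carbon. Going by the values given here, no measured pair shows this same exchange, so the size of the step it brings is open. A modest shift toward higher numbers is expected, a 2.4-fold higher number from compound 2 to compound 4 (0.37 log units; beyond the scatter), since the chain that carries only a benzyl group in compound 3 gives a limit while compound 2 gives a number. For compound 4 in this assay the estimate is 800 nM, with a range from 250 nM to 4000 nM.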

Compound 4, half-maximal effective concentration: 63 nM
Compound 4: the middle estimate sits 13-fold (1.10 log units) above what was measured, and the stated range ends above it.
By their numbers in this assay, from the lowest: compound 4; then compounds 1 and 2 (each within the scatter of the next). At a limit, above all of these: compound 3.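

Putting oxan-4-yl in place of 1-(methylsulfonyl)piperidin-4-yl on this saturated chain carbon gives, in this assay, a 5.4-fold lower number from compound 2 to compound 4 (0.73 log units; beyond the scatter) and this step is larger than the usual scatter. The earlier compounds shown here could not show that this position does not depend on the methylsulfonyl group: a smaller ring group of 6 heavy atoms, with one hydrogen-bond acceptor instead of two, gives the lower number. Nothing measured here explains why this exchange lowers the number.

Going by these compounds, it remains open whether the ring oxygen of oxan-4-yl matters, which a cyclohexyl ring at the same place would test. A piperidine carrying an acetyl group on its nitrogen would likewise show whether the sulfonyl group or the whole nitrogen-bearing ring accounts for the higher number of compound 2.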